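Cytotoxicity of three compounds and a forecast for a fourth

A few compounds are considered here, and "the series" means these few. Any claim that something is new, unique, unknown or untested is made for them only; others in the source may bear on it.

Of the compounds shown here, three built on a shared core have been tested in an ADME assay on Huh7.5.1 cells (Homo sapiens) for cytotoxicity, read by ATP content, with a stated time of 48 h; on this read-out higher numbers stand for lower toxicity in this test and lower numbers for higher toxicity in this test. Compound 1 `Cc1ccc(C)c(-c2nc(CN3CCC(C(=O)NCCCN4C[C@H](C)C[C@H](C)C4)CC3)c(C)o2)c1` gives 4070 nM. Compound 2 `Cc1ccccc1-c1nc(CN2CCC(C(=O)NCCCN3CCC(C(C)C)CC3)CC2)c(C)o1` gives 4280 nM, and compound 3 `Cc1oc(-c2c(Br)cccc2Br)nc1CN1CCC(C(=O)NCCCN2C[C@H](C)C[C@H](C)C2)CC1` gives 6500 nM. Going by the values given here, the only single-point step among them, a 1.6-fold higher number from compound 1 to compound 3 (0.20 log units; within the scatter), does not move the number beyond the scatter. Compound 2 stands with the second highest of the three numbers, within the scatter of both compound 1 and compound 3.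

Compound 4 `CCCN(CCC)CCNC(=O)C1CCN(Cc2nc(-c3ccccc3C)oc2C)CC1` is not yet measured. Its change from compound 2 is dipropylamino in place of (4-isopropylpiperidin-1-yl)methyl on a saturated chain carbon, two bonds along the chain from an amide-type nitrogen. Among the compounds with values here, no measured step touches this part of the molecule, so the only guide is the narrow spread of the three values shown, which all fall within the scatter of each other. On that basis, the step from compound 2 to compound 4 is expected to stay within the scatter, a 1.0-fold higher number from compound 2 to compound 4 (0.00 log units; within the scatter). Compound 4 is therefore estimated at 4300 nM in this assay, with a range from 2000 nM to 9500 nM.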

Compound 4, half-maximal cytotoxic concentration: 30500 nM
Estimate against measurement, compound 4: 7.1-fold (0.85 log units) below; the whole stated range lies below it.
By their numbers in this assay, from the lowest: compounds 1, 2 and 3 (each within the scatter of the next); then compound 4.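

In this assay, this swap gives a 7.1-fold higher number from compound 2 to compound 4 (0.85 log units; beyond the scatter), the first step shown that lies beyond the scatter, so this part of the molecule can shift the read-out towards lower toxicity in this test. Unlike the step on the aromatic carbon, it replaces a group carrying a six-membered non-aromatic ring with an open-chain group that has fewer heavy atoms; cut one bond further out, it reads as 2-(4-isopropylpiperidin-1-yl)ethyl to (dipropylamino)methyl, so the ring and the chain change together in a single step. No measurement shown here accounts for the size of this step.

Which part of the swap carries the step remains open, as does whether it would hold on other cores. A diethylamino group or a morpholine ring at this place would add further points of comparison.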